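From a Thioester to a Difluoropropyl Amide

The source may hold more compounds than are shown below. What is called first, only, known or untested is meant among the compounds shown, and "the series" means these compounds.

For the measured compounds named here, in a functional assay on isolated protein for inhibition of Glucose-dependent insulinotropic receptor (Rattus norvegicus), read by HTRF and cAMP accumulation (on this read-out lower numbers stand for smaller maximal responses and higher numbers for larger maximal responses), compound 2 `Cc1nc(S(C)(=O)=O)ccc1Oc1ncnc(OC2CCN(C(=O)SC3CCC3)CC2)c1F` gives 81%, while compound 1 `Cc1nc(S(C)(=O)=O)ccc1Oc1ncnc(OC2CCN(C(=O)SC3(C)CC3)CC2)c1F` gives 77%; the single measured step, a number 4 percentage points higher from compound 1 to compound 2 (within the scatter), lies within the scatter, so the two maximal responses cannot be told apart. Compound 3 `CCC(F)(F)C(=O)N1CCC(Oc2ncnc(Oc3ccc(S(C)(=O)=O)nc3C)c2F)CC1` has not yet been measured in this assay. It differs from compound 2 by 1,1-difluoropropyl in place of cyclobutylsulfanyl on a carbonyl carbon. Going by the values given here, no measured step exchanges the sulfur-linked group for a carbon-linked one; the only step at hand, a number 4 percentage points higher from compound 1 to compound 2 (within the scatter), merely shows that changing the ring on the sulfur left the maximal response where it was. Compound 3 is therefore expected to give 78%, with a range from 60% to 92%, the range set wider than usual since the change is larger than the one measured. The expected step of a number 3 percentage points lower from compound 2 to compound 3 (within the scatter) is thus estimated to stay within the scatter.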

Compound 3, largest response reached (reported as efficacy), in percent of the reference or control that the assay uses: 90%
The estimate for compound 3 lay 12 percentage points below the measured number; low and high end bracket the measured number.
By their numbers in this assay, from the lowest: compounds 1, 2 and 3 (each within the scatter of the next, the first and the last beyond it).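

In this assay, the carbonyl carbon whose other neighbour is the amide-type nitrogen in a ring proves able to carry a group with neither sulfur nor a ring while the maximal response stays high: replacing cyclobutylsulfanyl with 1,1-difluoropropyl gives a number 9 percentage points higher from compound 2 to compound 3 (within the scatter), so these two cannot be told apart. Set against the 1-methylcyclopropyl group on sulfur, the same kind of exchange gives a number 13 percentage points higher from compound 1 to compound 3 (beyond the scatter), the first step here to pass the scatter, though only a modest one. Nothing measured accounts for either step.

The compounds shown leave open what a plain propyl group on this carbonyl carbon would give, and so what the two fluorine atoms contribute. They also do not show how a cyclobutyl group attached directly through carbon, or an amine in the same place, would read.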